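Fluoro Substitution and Vero Cell Cytotoxicity in Three Analogues

The source may hold more compounds than are shown below. What is called first, only, known or untested is meant among the compounds shown, and "the series" means these compounds.

Compound 1 `CO/N=C1/C(=O)N(Cc2cn(CC(=O)N3CCC[C@@H]4CN(c5c(F)cc6c(=O)c(C(=O)O)cn(C7CC7)c6c5OC)C[C@@H]43)nn2)c2ccccc21`: 128 ug/mL
Compound 2 `CO/N=C1/C(=O)N(Cc2cn(CC(=O)N3CCC[C@@H]4CN(c5c(F)cc6c(=O)c(C(=O)O)cn(C7CC7)c6c5OC)C[C@@H]43)nn2)c2ccc(F)cc21`: 32 ug/mL
Compound 3 `COc1c(N2C[C@H]3CCCN(C(=O)Cn4cc(CN5C(=O)/C(=N/NC(N)=S)c6ccccc65)nn4)[C@H]3C2)c(F)cc2c(=O)c(C(=O)O)cn(C3CC3)c12`: 16 ug/mL

These three compounds were tested in an ADME assay on Vero cells (Chlorocebus sabaeus) for cytotoxicity, read by MTT assay, with a stated time of 72 h; on this read-out lower numbers stand for higher toxicity in this test and higher numbers for lower toxicity in this test. Compound 2 differs from compound 1 by fluoro in place of hydrogen on an aromatic carbon, and that step gives a 4.0-fold lower number from compound 1 to compound 2 (0.60 log units; beyond the scatter). The core of compound 3 differs from that of compound 1 by a group of 4 heavy atoms (1 carbon, 2 nitrogen, 1 sulfur; no ring) in place of a group of 2 heavy atoms (1 carbon, 1 oxygen; no ring), on a double-bonded nitrogen, with an 8.0-fold lower number from compound 1 to compound 3 (0.90 log units; beyond the scatter). Compound 4 `COc1c(N2C[C@H]3CCCN(C(=O)Cn4cc(CN5C(=O)/C(=N/NC(N)=S)c6cccc(F)c65)nn4)[C@H]3C2)c(F)cc2c(=O)c(C(=O)O)cn(C3CC3)c12` has not yet been measured in this assay; it differs from compound 3 by fluoro in place of hydrogen on an aromatic carbon. This is the same kind of change as from compound 1 to compound 2, but not the same: in compound 4 the fluoro sits ortho to a fused ring and meta to a fused ring, whereas in compound 2 it sits meta to a fused ring and para to a fused ring. Resting on a 4.0-fold lower number from compound 1 to compound 2 (0.60 log units; beyond the scatter), compound 4 is expected to show a 3.2-fold lower number from compound 3 to compound 4 (0.51 log units; beyond the scatter) in this assay. Compound 4 is therefore estimated at 5 ug/mL, with a likely range from 2 ug/mL to 16 ug/mL.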

Compound 4, half-maximal cytotoxic concentration: 8 ug/mL
Compound 4: the middle estimate sits 1.6-fold (0.20 log units) below what was measured; measured number inside the range.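

In this assay, fluoro in place of hydrogen on an aromatic carbon gives a 2.0-fold lower number from compound 3 to compound 4 (0.30 log units; within the scatter). The two steps cannot be told apart on these numbers: the same change on two cores in this assay, a 4.0-fold lower number (0.60 log units; beyond the scatter) from compound 1 to compound 2 and a 2.0-fold lower number (0.30 log units; within the scatter) from compound 3 to compound 4, 2.0-fold (0.30 log units) apart, within the scatter of two such steps. Among these compounds, this agrees with the change carrying over between the two cores, but it does not establish that it does: the new step on its own lies within the scatter, only two pairs are available, and the fluoro occupies a different place in compound 4 than in compound 2.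

The compounds shown leave open whether fluoro placed as in compound 2 would give a similar step on the core of compound 3. They also leave open how a chloro or methyl group on that aromatic carbon would read in this assay.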